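From Compound 3 to Compound 4: A New Side Chain

A few compounds are considered here, and "the series" means these few. Any claim that something is new, unique, unknown or untested is made for them only; others in the source may bear on it.

In an ADME assay on Huh-7 cells (Homo sapiens) for cytotoxicity, with a stated time of 72 h (on this read-out higher numbers stand for lower toxicity in this test and lower numbers for higher toxicity in this test), compound 3 `CCC(C)n1nc(-c2cccs2)c(O)c(C2=NS(=O)(=O)c3cc(NS(C)(=O)=O)ccc3N2)c1=O` reads > 33000 nM as a limit of the assay, not a number. Compound 2 `CCCC(C)n1nc(-c2cccs2)c(O)c(C2=NS(=O)(=O)c3cc(NS(C)(=O)=O)ccc3N2)c1=O` reads > 33000 nM as a limit too. Compound 1 `CCC(C)CCn1nc(-c2cccs2)c(O)c(C2=NS(=O)(=O)c3cc(NS(C)(=O)=O)ccc3N2)c1=O` reads > 1000 nM as a limit too. Compound 3 therefore has no exact place on the scale, only a shared position (the limit of > 33000 nM in this assay, at which 2 of the 3 values shown sit).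

Compound 4 `CS(=O)(=O)Nc1ccc2c(c1)S(=O)(=O)N=C(c1c(O)c(-c3cccs3)nn(CC3(C(F)(F)F)CC3)c1=O)N2` keeps the shared core but carries a new group on the aromatic nitrogen ((1-(trifluoromethyl)cyclopropyl)methyl in place of sec-butyl on an aromatic nitrogen): (1-(trifluoromethyl)cyclopropyl)methyl in place of sec-butyl.

Three measured steps alter this same side chain, namely a step that the two limits leave unreadable from compound 1 to compound 2 and a step that the two limits leave unreadable from compound 1 to compound 3 and also a step that the two limits leave unreadable from compound 2 to compound 3 and none of them has a readable size. They offer no measured effect to carry over to the new group.

Since compound 3 stands at the limit > 33000 nM with no number behind it, no step beyond the usual scatter is expected in this assay and no direction can be given. The estimated change is a number no higher from compound 3 to compound 4 (the limit leaves the size open) and remains only an expectation. The estimated value for compound 4 is 33000 nM within an expected range from 12000 nM to 60000 nM and the assay may again report only a limit.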

Compound 4, half-maximal cytotoxic concentration: > 1000 nM
Compound 4: a limit, no number; the forecaster's own chance of this, stated with the estimate: 75%; the middle value is on the limit's open side.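

In this assay compound 4 gives > 1000 nM, a limit of the assay and not a number. Compound 1, compound 2 and compound 3 also carry only limits, and none of their steps to compound 4 can be read. As far as these compounds go, whether these side chains on the aromatic nitrogen change toxicity in this test, and in which direction, remains open.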